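This account rests on a few compounds, and the source may have more. Where it says the series, first, only, none or still open, it means among the compounds named here.

Working notes on the series.

Three compounds of the shared core carry a measured number. Compound 1 `Cc1ccc(-c2nn(-c3ccccc3)cc2-c2nc3ccccc3n2C(=O)c2ccccc2)cc1` gives in an ADME assay on HEK-293T cells (Homo sapiens) for cytotoxicity, read by MTT assay, with a stated time of 24 h (on this read-out higher numbers stand for lower toxicity in this test and lower numbers for higher toxicity in this test), a value of 204000 nM. Compound 2 `Cc1ccc(-c2nn(-c3ccccc3)cc2-c2nc3ccccc3n2C(=O)c2cncc(C)c2)cc1` gives in this assay a value of 155000 nM. Compound 3 `Cc1cncc(C(=O)n2c(-c3cn(-c4ccccc4)nc3-c3ccc(C(F)(F)F)cc3)nc3ccccc32)c1` gives in this assay a value of 123000 nM. Compound 2 to compound 1 is one change, (phenyl in place of 5-methylpyridin-3-yl on a carbonyl carbon), and it made a 1.3-fold higher number from compound 2 to compound 1 (0.12 log units; within the scatter). Compound 2 to compound 3 is a second change, (trifluoromethyl in place of methyl on an aromatic carbon), and it made a 1.3-fold lower number from compound 2 to compound 3 (0.10 log units; within the scatter). All three numbers sit within the scatter of one another.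

Compound 4 `O=C(c1ccccc1)n1c(-c2cn(-c3ccccc3)nc2-c2ccc(C(F)(F)F)cc2)nc2ccccc21` is not yet measured. For the measured compounds named here, it differs from compound 3 by phenyl in place of 5-methylpyridin-3-yl on a carbonyl carbon, which is the same change as the one from compound 2 to compound 1, at the same place; the cores of the two pairs differ by the trifluoromethyl-for-methyl change noted above. On that single earlier step, the change from compound 3 to compound 4 is expected to make a 1.3-fold higher number from compound 3 to compound 4 (0.11 log units; within the scatter) in this assay, a step that would again stay within the scatter. Compound 4 is therefore estimated at 160000 nM in this assay, with a likely range from 80000 nM to 320000 nM. This rests on one precedent only and is held loosely.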

Compound 4, half-maximal cytotoxic concentration: 168000 nM
The estimate for compound 4 lay 1.1-fold (0.02 log units) below the measured number; the range from low to high includes it.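

Phenyl in place of 5-methylpyridin-3-yl on a carbonyl carbon makes a 1.4-fold higher number from compound 3 to compound 4 (0.14 log units; within the scatter) in this assay, and this step agrees with the one seen on the methyl-bearing core: the same change on two cores in this assay, a 1.3-fold higher number (0.12 log units; within the scatter) from compound 2 to compound 1 and a 1.4-fold higher number (0.14 log units; within the scatter) from compound 3 to compound 4, 1.0-fold (0.02 log units) apart, within the scatter of two such steps. Trifluoromethyl in place of methyl on an aromatic carbon makes a 1.2-fold lower number from compound 1 to compound 4 (0.08 log units; within the scatter), which agrees in the same way with its earlier counterpart on the core bearing the 5-methylpyridin-3-yl group: the same change on two cores in this assay, a 1.3-fold lower number (0.10 log units; within the scatter) from compound 2 to compound 3 and a 1.2-fold lower number (0.08 log units; within the scatter) from compound 1 to compound 4, 1.0-fold (0.02 log units) apart, within the scatter of two such steps. Across these four compounds, each change therefore reads the same on both cores, but every step stays within the scatter, so this shows only that neither change moved the number measurably on either core, not that a real effect of a given size carries from one core to another.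

The compounds shown leave open whether any group on the carbonyl carbon can move the number beyond the scatter, since only two aromatic groups appear there. An amine or a longer chain in that place, or a carboxylic acid on an aromatic carbon, would test this.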